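A few compounds are considered here, and "the series" means these few. Any claim that something is new, unique, unknown or untested is made for them only; others in the source may bear on it.

Compound 1 `CCC[C@H](NC(=O)[C@@H]1[C@H]2[C@@H](CN1C(=O)[C@@H](NC(=O)NC1([C@H]3CCCS3(=O)=O)CCCCC1)C(C)(C)C)C2(C)C)C(=O)C(=O)NC1CC1` and compound 2 `CC(C)(C)[C@H](NC(=O)NC1([C@H]2CCCS2(=O)=O)CCCCC1)C(=O)N1C[C@@H]2[C@H]([C@H]1C(=O)N[C@@H](CCC1CC1)C(=O)C(=O)NC1CC1)C2(C)C` share one core and differ only by cyclopropyl in place of methyl on a saturated chain carbon, three bonds along the chain from an amide-type nitrogen and a carbonyl carbon. In an ADME assay on the whole organism (plasma) for pharmacokinetics, with Rattus norvegicus as the target, with a stated time of 24 h, at a dose of 10 mg/kg by the oral route (on this read-out higher numbers stand for higher exposure at the dose given and lower numbers for lower exposure), compound 1 gives 203 ng.h/mL and compound 2 gives 352 ng.h/mL, so that a 1.7-fold higher number from compound 1 to compound 2 (0.24 log units; within the scatter). Compound 3 `CCC[C@H](NC(=O)[C@@H]1[C@H]2[C@@H](CN1C(=O)[C@@H](NC(=O)NC1([C@H]3CCCS3(=O)=O)CCCCC1)C1(C)CCCCC1)C2(C)C)C(=O)C(=O)NC1CC1` differs from compound 1 in its core by 1-methylcyclohexyl in place of tert-butyl on a saturated chain carbon bound to an amide-type nitrogen and a carbonyl carbon; in this assay compound 3 gives 862 ng.h/mL, and a 4.2-fold higher number from compound 1 to compound 3 (0.63 log units; beyond the scatter), leaving compound 3 with the highest of the three numbers. Compound 4 `CC1([C@H](NC(=O)NC2([C@H]3CCCS3(=O)=O)CCCCC2)C(=O)N2C[C@@H]3[C@H]([C@H]2C(=O)N[C@@H](CCC2CC2)C(=O)C(=O)NC2CC2)C3(C)C)CCCCC1` is not yet measured. Relative to compound 3 it shows (cyclopropyl in place of methyl on a saturated chain carbon, three bonds along the chain from an amide-type nitrogen and a carbonyl carbon), which is the same change as that from compound 1 to compound 2, made at the same place, but now on the core of compound 3. Among the compounds with values here, the only measured instance of this change moved the number little, and nothing among the measured compounds suggests the core of compound 3 would respond differently. Because a 1.7-fold higher number from compound 1 to compound 2 (0.24 log units; within the scatter), the expected step in this assay is a 1.5-fold higher number from compound 3 to compound 4 (0.18 log units; within the scatter), with the usual scatter of such measurements kept in mind. For compound 4 the estimated value in this assay is 1300 ng.h/mL, with a likely range from 550 ng.h/mL to 3000 ng.h/mL.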

Compound 4, area under the concentration-time curve: 1120 ng.h/mL
The estimate for compound 4 lay 1.2-fold (0.06 log units) above the measured number, within the range that was stated.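

Notes on carrying the changes across cores: in this assay, cyclopropyl in place of methyl gives a 1.3-fold higher number from compound 3 to compound 4 (0.11 log units; within the scatter), and this step agrees with its earlier counterpart on the other core: the same change on two cores in this assay, a 1.7-fold higher number (0.24 log units; within the scatter) from compound 1 to compound 2 and a 1.3-fold higher number (0.11 log units; within the scatter) from compound 3 to compound 4, 1.3-fold (0.13 log units) apart, within the scatter of two such steps

The larger change, 1-methylcyclohexyl in place of tert-butyl, gives a 3.2-fold higher number from compound 2 to compound 4 (0.50 log units; beyond the scatter), and it also carries over: the same change on two cores in this assay, a 4.2-fold higher number (0.63 log units; beyond the scatter) from compound 1 to compound 3 and a 3.2-fold higher number (0.50 log units; beyond the scatter) from compound 2 to compound 4, 1.3-fold (0.13 log units) apart, within the scatter of two such steps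

Each change therefore kept its size on the second core, but this rests on just these four compounds, so it shows neither that the changes would carry to any other core nor why exposure moves as it does.

Still open, going by these compounds, is how a group other than cyclopropyl, such as a longer chain or an amine, would behave at the same place on the chain. Also open, on these data alone, is whether a ring larger than cyclohexyl, or one bearing a carboxylic acid, would extend the step seen with 1-methylcyclohexyl.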